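The compounds below may be only part of what the source reports. "The series", "measured", "known", "first", "only" and "open" are said of these compounds alone.

Measured in a functional assay on HL-60 cells (Homo sapiens) for cytotoxicity, read by MTT assay, with a stated time of 72 h; a higher number here means a weaker inhibitor, a lower number a stronger inhibitor:
- compound 1 `Cc1ccc(S(=O)(=O)c2nc3ccccc3nc2Nc2ccc(Cl)cc2)cc1` gives 17500 nM
- compound 2 `COc1ccc(S(=O)(=O)c2nc3ccccc3nc2Nc2cc(OC)cc(OC)c2)cc1` gives 1710 nM

Compound 2 holds the lower of the two numbers, and its gap to compound 1 lies beyond the scatter. Compound 3 `COc1ccc(S(=O)(=O)c2nc3ccccc3nc2Nc2ccc(Cl)cc2)cc1` has 4-chlorophenyl in place of 3,5-dimethoxyphenyl on a nitrogen on an aromatic ring relative to compound 2. Compound 1 also carries 4-chlorophenyl there and gives 17500 nM in this assay so a rise beyond the scatter, towards a weaker inhibitor, is expected. The estimated change is a 5.8-fold higher number from compound 2 to compound 3 (0.77 log units; beyond the scatter) in that direction. Compound 3 is expected at 10000 nM with an estimated range of 3500 nM to 28000 nM when measured.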

Compound 3, half-maximal inhibitory concentration: 19600 nM
For compound 3 the middle estimate is 2.0-fold (0.29 log units) below the measured one; measured number inside the range.
By their numbers in this assay, from the lowest: compound 2; then compounds 1 and 3 (each within the scatter of the next).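

In this assay, 4-chlorophenyl in place of 3,5-dimethoxyphenyl on a nitrogen on an aromatic ring gives an 11-fold higher number from compound 2 to compound 3 (1.06 log units; beyond the scatter), showing that this change alone, with the rest of the molecule held constant, has a large effect on the number. Methoxy in place of methyl on an aromatic carbon, by contrast, gives a 1.1-fold higher number from compound 1 to compound 3 (0.05 log units; within the scatter), so that exchange does not separate these two compounds. Nothing available explains the size of the first step. From the compounds shown here alone, whether the lower number of compound 2 depends on both methoxy groups or on the absence of chlorine remains open. So does the outcome with an amine or a carboxylic acid on that phenyl ring.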